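The compounds below may be only part of what the source reports. "The series", "measured", "known", "first", "only" and "open" are said of these compounds alone.

The measurements here come from an ADME assay on HCT-116 cells (Homo sapiens) for cytotoxicity, read by CellTiter-Glo, with a stated time of 72 h; a higher number here means a weaker inhibitor, a lower number a stronger inhibitor. Compound 1, with the structure `Cc1cc(C)c(S(=O)(=O)N2CCC(N3CCC(CCO)CC3)CC2)c(C)c1`, is one of the two compounds measured. Its result is a limit of the assay rather than a number: compound 1 gives > 5000 nM. Compound 2, with the structure `CC1CCN(C2CCN(S(=O)(=O)c3cccc(-c4ccccc4F)c3)CC2)CC1`, is the other measured compound, and its result is also a limit, at > 5000 nM. For the measured compounds named here, both measured compounds therefore sit at the same point, (the limit of > 5000 nM in this assay, at which 2 of the 2 values shown sit), so neither one can be placed above or below the other, and no step between two measured compounds can be read from these data.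

Compound 3, with the structure `Cc1cc(C)c(S(=O)(=O)N2CCC(N3CCC(O)CC3)CC2)c(C)c1`, has not yet been measured. It differs from compound 1 in one place: hydroxy in place of 2-hydroxyethyl on a saturated ring carbon. Going by the values given here, with no measured step to guide the expectation, the change from compound 1 to compound 3 is expected to stay within the scatter of this assay, and compound 3 is estimated to land at 8000 nM, between 4000 nM and 25000 nM. That estimate amounts to an expected step that the limit leaves unreadable from compound 1 to compound 3, with compound 3 most likely returning a limit once more.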

Compound 3, half-maximal inhibitory concentration: > 5000 nM
Compound 3 ended at the assay's limit; the forecaster's own chance of this, stated with the estimate: 85%; the middle value lies beyond the limit too.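

For the compounds shown here, no step from compound 1 to compound 3 can be read in this assay, since both results are limits of the assay rather than numbers: the limit of > 5000 nM in this assay, at which 3 of the 3 values shown sit.

The compounds shown leave open whether hydroxy in place of 2-hydroxyethyl changes the result at all, and which structures in this series would return a readable number.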